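Compound 1 to compound 4: losing the trifluoromethoxy group

A few compounds are considered here, and "the series" means these few. Any claim that something is new, unique, unknown or untested is made for them only; others in the source may bear on it.

Measured in a physicochemical assay for lipophilicity, measured as octanol-water partition; a higher number here means a more lipophilic compound, a lower number a more polar compound
- compound 1 `COc1ccc2c(c1)[n+]([O-])c(C#N)c(-c1ccc(OC(F)(F)F)cc1)[n+]2[O-]` gives 1.33
- compound 2 `N#Cc1c(-c2ccco2)[n+]([O-])c2ccc(Cl)cc2[n+]1[O-]` gives 1.11
- compound 3 `Cc1ccc2c(c1)[n+]([O-])c(C#N)c(-c1ccco1)[n+]2[O-]` gives 0.845

On these numbers, compound 1 and compound 2 sit within the scatter of each other, while compound 3 lies lower than compound 1, beyond the scatter.

Compound 4 `COc1ccc2c(c1)[n+]([O-])c(C#N)c(-c1ccccc1)[n+]2[O-]` has not yet been measured in this assay. It differs from compound 1 by hydrogen in place of trifluoromethoxy on an aromatic carbon, para to a large group (hydrogen in place of trifluoromethoxy on an aromatic carbon). Within the data shown here, no measured pair removes this group. Among the measured compounds shown here, only one measured step bears on the change, and only loosely: methyl in place of chloro on an aromatic carbon gave a number 0.27 log units lower from compound 2 to compound 3 (within the scatter) as its result. Losing the whole trifluoromethoxy group is a larger structural change than that exchange, so a downward step beyond the scatter is expected, though with wide uncertainty. The estimated step is a number 0.73 log units lower from compound 1 to compound 4 (beyond the scatter) (an expectation, not a measurement). For compound 4 the estimated value is 0.6 (expected range 0.25 to 1).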

Compound 4, partition coefficient: 1.58
The estimate for compound 4 lay 0.98 log units below the measured number, outside the stated range (above it).
By their numbers in this assay, from the lowest: compounds 3, 2, 1 and 4 (each within the scatter of the next, the first and the last beyond it).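

In this assay, hydrogen in place of trifluoromethoxy on an aromatic carbon, para to a large group, gives a number 0.25 log units higher from compound 1 to compound 4 (within the scatter). Among these compounds, this is the first measured pair that changes this position: all 5 heavy atoms of the trifluoromethoxy group leave, yet the two compounds cannot be told apart in this read-out, something the step between the chloro and methyl compounds could not show. No evidence at hand accounts for this result.

The compounds shown hold only hydrogen or trifluoromethoxy at this place, so the outcome with an amine or a carboxylic acid there remains open. Going by these compounds, whether the same exchange gives a similar step in compounds carrying chloro or methyl instead of methoxy also remains open.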